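Benzylpiperidine amides of a hindered phenol: a fluorobenzyl variant

The source may hold more compounds than are shown below. What is called first, only, known or untested is meant among the compounds shown, and "the series" means these compounds.

Measured so far:
compound 1, `CC(C)(C)c1cc(CCC(=O)NC2CCN(Cc3ccccc3)CC2)cc(C(C)(C)C)c1O`, 90200 nM
compound 2, `CC(C)(C)c1cc(CCC(=O)NCCC2CCN(Cc3ccccc3)CC2)cc(C(C)(C)C)c1O`, 94100 nM
compound 3, `Cc1ccccc1CN1CCC(CCNC(=O)/C=C/c2cc(C(C)(C)C)c(O)c(C(C)(C)C)c2)CC1`, 69300 nM

All three compounds share the hindered phenol and the benzylpiperidine, and all three were read in an assay on isolated protein for inhibition of Amine oxidase [flavin-containing] A (Homo sapiens), read by fluorescence, with stated times of 15 min and 20 min; a lower number here means a stronger inhibitor, a higher number a weaker inhibitor. Compound 3 gives the lowest of the three numbers, yet its gap to compound 1 and its gap to compound 2 both lie inside the scatter of repeated runs, so nothing in this set separates one compound from another.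

Compound 4, `CC(C)(C)c1cc(/C=C/C(=O)NCCC2CCN(Cc3ccc(F)cc3)CC2)cc(C(C)(C)C)c1O`, is the next member. It follows from compound 3 by a single change, (4-fluorophenyl in place of 2-methylphenyl on a saturated chain carbon bound to an amine nitrogen in a ring), the benzyl on the piperidine nitrogen now carrying fluorine rather than a methyl. Going by the values given here, no measured pair in the set isolates such a change, and compound 2, with a plain benzyl at the same place, sits with the others inside the scatter.

The expectation for compound 4 is therefore no step beyond the scatter, a 1.1-fold higher number from compound 3 to compound 4 (0.03 log units; within the scatter). Compound 4 is estimated at 75000 nM, with a likely range from 30000 nM to 190000 nM.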

Compound 4, half-maximal inhibitory concentration: 59600 nM
Compound 4: the middle estimate sits 1.3-fold (0.10 log units) above what was measured, within the range that was stated.
By their numbers in this assay, from the lowest: compounds 4, 3, 1 and 2 (each within the scatter of the next).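

Going by these compounds alone, at the place on a saturated chain carbon bound to an amine nitrogen in a ring, 2-methylbenzyl to 4-fluorobenzyl gives the first single-change comparison: a 1.2-fold lower number from compound 3 to compound 4 (0.07 log units; within the scatter) in this assay. On this pair, the 2-methylphenyl and 4-fluorophenyl groups cannot be told apart in this read-out, so this exchange does not separate the two compounds. No available measurement bears on the reason for this result.

Still open, from the compounds shown here alone, is whether any other group at this place, such as a benzyl carrying a carboxylic acid or a dimethylamino group, would give a step beyond the scatter. Going by these compounds, it is also open whether a longer chain between the amide nitrogen and the ring would separate any compound from this cluster.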